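This account rests on a few compounds, and the source may have more. Where it says the series, first, only, none or still open, it means among the compounds named here.

Of the compounds shown here, two sharing one core have been measured in a functional assay on CHO cells for inhibition of metabotropic glutamate receptor 5 (Rattus norvegicus), read by FLIPR and calcium flux; on this read-out lower numbers stand for stronger inhibition and higher numbers for weaker inhibition. Compound 1 `Cc1ccc2ccc(-c3cccc(C(F)(F)F)c3)cc2n1` carries a trifluoromethyl group, and in this assay compound 1 gives only a limit, > 10000 nM, not a number. Compound 2 `Cc1ccc2ccc(-c3cc(F)cc(C#N)c3)cc2n1` carries a nitrile and a fluoro group, and in this assay compound 2 gives 0.8 nM. Within the data shown here, that is the only number so far; the other result is the limit of > 10000 nM in this assay, at which 1 of the 2 values shown sits. Compound 3 `Cc1ccc2ccc(-c3cc(O)cc(C#N)c3)cc2n1` differs from compound 2 by hydroxy in place of fluoro on an aromatic carbon. The expected step in this assay is a weakening beyond the scatter, a 6.3-fold higher number from compound 2 to compound 3 (0.80 log units; beyond the scatter). Compound 3 is estimated at 5 nM, likely between 1 nM and 30 nM.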

Compound 3, half-maximal inhibitory concentration: 360 nM
The estimate for compound 3 lay 72-fold (1.86 log units) below the measured number, outside the stated range (above it).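

In this assay this position proves highly sensitive: with the nitrile unchanged, putting hydroxy in place of fluoro on this aromatic carbon gives a 450-fold higher number from compound 2 to compound 3 (2.65 log units; beyond the scatter). Even so, compound 3 still gives a measured number rather than a limit, so this change weakens inhibition without abolishing it in this series. Nothing measured here explains why this single change costs so much. Still open, from the compounds shown here alone, is whether the loss comes from gaining hydroxy or from losing fluoro. A methoxy group or an amine on this carbon could help separate the two.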